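This account rests on a few compounds, and the source may have more. Where it says the series, first, only, none or still open, it means among the compounds named here.

Series notes on the shared core of compound 3 `NS(=O)(=O)c1ccc(-c2nc(C(c3ccc(F)cc3)c3ccc(F)cc3)sc2CC(=O)O)cc1`. In an in vitro functional assay on HEK285-7 cells for antagonist activity at prostaglandin D2 receptor 2 (Homo sapiens), read by BRET and beta-arrestin recruitment (on this read-out higher numbers stand for larger maximal responses and lower numbers for smaller maximal responses), compound 3 gives 80%, level with compound 1 `O=C(O)Cc1sc(C(c2ccc(F)cc2)c2ccc(F)cc2)nc1-c1ccnc(N2CCC2)c1`, which in this assay gives 80%, and with compound 2 `O=C(O)Cc1sc(C(c2ccc(F)cc2)c2ccc(F)cc2)nc1-c1ccco1`, which in this assay gives 80%. The steps of no change at the digits printed from compound 1 to compound 2 (within the scatter), no change at the digits printed from compound 1 to compound 3 (within the scatter) and no change at the digits printed from compound 2 to compound 3 (within the scatter) all stayed within the scatter, although each exchanged the whole aryl group on an aromatic carbon of the core. Compound 4 `N#Cc1ccc(-c2nc(C(c3ccc(F)cc3)c3ccc(F)cc3)sc2CC(=O)O)cc1` differs from compound 3 by cyano in place of sulfamoyl on an aromatic carbon. For the measured compounds named here, no measured step exchanges one substituent of the phenyl ring for another; the nearest guidance is that the three measured exchanges at the same aromatic carbon, each a far larger change, left the maximal response unmoved in this assay. A step of no change at the digits printed from compound 3 to compound 4 (within the scatter) is therefore expected, that is, none beyond the scatter. Compound 4 is expected to give 80% in this assay, with a range from 65% to 95%.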

Compound 4, largest response reached (reported as efficacy), in percent of the reference or control that the assay uses: 30%
The estimate for compound 4 lay 50 percentage points above the measured number, and the stated range ends above it.
By their numbers in this assay, from the lowest: compound 4; then compounds 1, 2 and 3 (each within the scatter of the next).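

In this assay, for the compounds shown here, this aromatic carbon of the core is less tolerant than the earlier compounds suggested: with the phenyl ring kept, cyano in place of sulfamoyl para to a large group gives a number 50 percentage points lower from compound 3 to compound 4 (beyond the scatter) and so shows that one substituent exchange can move the maximal response. The other two comparisons give a number 50 percentage points lower from compound 2 to compound 4 (beyond the scatter) and a number 50 percentage points lower from compound 1 to compound 4 (beyond the scatter), which sets 4-cyanophenyl apart from 4-sulfamoylphenyl, furan-2-yl and 2-(azetidin-1-yl)pyridin-4-yl, the three groups that stay level with one another. Nothing available here accounts for this drop.

The compounds shown cannot separate an effect of introducing the cyano group from an effect of removing the sulfamoyl group. As far as these compounds go, a primary carboxamide, a methyl sulfone or a plain hydrogen at that place on the phenyl ring remains open, as does whether any of these stays level with compound 3 or falls with compound 4.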